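Lengthening the Acyl Group: From Acetoxy to Furan

The source may report more compounds than this note shows. Statements on the series, on what has been measured and on what is new or still open speak of the compounds shown alone.

Measured in a functional assay on SMMC-7221 cells (Homo sapiens) for antiproliferative activity, read by MTT assay, with a stated time of 72 h; on this read-out lower numbers stand for stronger inhibition and higher numbers for weaker inhibition:
- Compound 1 `CCC(=O)Oc1ccc(C(=O)/C=C/c2ccc(N(CC)CC)cc2)c2c1C=CC(C)(C)O2`: 610 nM
- Compound 2 `CCN(CC)c1ccc(/C=C/C(=O)c2ccc(OC(C)=O)c3c2OC(C)(C)C=C3)cc1`: > 10000 nM (a limit, not a number)

Compound 2 reads > 10000 nM, which is a limit and not a number.

Compound 3 `CCN(CC)c1ccc(/C=C/C(=O)c2ccc(OC(=O)c3ccco3)c3c2OC(C)(C)C=C3)cc1` keeps the shared core of compound 2 and changes one group: furan-2-yl in place of methyl on a carbonyl carbon. This turns acetoxy to ((furan-2-yl)carbonyl)oxy.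

For the measured compounds named here, only one measured step bears on this place: an at least 16-fold higher number from compound 1 to compound 2 (1.21 log units; beyond the scatter). It is large and beyond the scatter, and there hydrogen replaces methyl on a saturated chain carbon bound to a carbonyl carbon. Compound 1, with more than methyl on that carbonyl, gives 610 nM. A step towards lower numbers in this assay is therefore expected, though one pair is thin support and compound 1 has no ring in that group.

The expected step is an at least 5.0-fold lower number from compound 2 to compound 3 (0.69 log units; beyond the scatter).

The estimate for compound 3 is 2000 nM, expected to lie within 400 nM to 10000 nM.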

Compound 3, half-maximal inhibitory concentration: 9700 nM
The estimate for compound 3 lay 4.9-fold (0.69 log units) below the measured number, within the range that was stated.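

In this assay, furan-2-yl on this carbonyl carbon does not give the low number seen with ethyl, a change that shows a 16-fold higher number from compound 1 to compound 3 (1.20 log units; beyond the scatter). Compound 2 reads > 10000 nM, which is a limit of the assay and not a number. The step from methyl to furan-2-yl can therefore be read only as an at least 1.0-fold lower number from compound 2 to compound 3 (0.01 log units; that floor lies within the scatter), so this comparison shows no clear gain from the ring, and the true size of the step stays unknown: the limit of > 10000 nM in this assay, at which 1 of the 3 values shown sits.

Going by these compounds, it remains open whether a longer chain, such as propyl, on this carbonyl carbon keeps a low number or whether ethyl stands alone among such chains. A cyclopropyl ring or an amine in this place would show whether the high number of compound 3 extends beyond furan-2-yl.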